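This account rests on a few compounds, and the source may have more. Where it says the series, first, only, none or still open, it means among the compounds named here.

The compounds measured so far, in a functional assay on A549 cells (Homo sapiens) for inhibition, read by MTT assay, with a stated time of 72 h; on this read-out higher numbers stand for weaker inhibition and lower numbers for stronger inhibition:

Compound 1, `CN(C(=O)NC(=O)c1cccc(C(F)(F)F)c1)c1nc(C(F)(F)F)c(C(=O)N/N=C/c2ccccc2C(F)(F)F)s1`, gives 12.1 ug/mL in this assay. Compound 2, `CN(C(=O)NC(=O)c1ccccc1F)c1nc(C(F)(F)F)c(C(=O)N/N=C/c2cc(C(F)(F)F)cc(C(F)(F)F)c2)s1`, gives 5.43 ug/mL in this assay. Compound 3, `CNc1nc(C)c(C(=O)N/N=C/c2ccc(C(F)(F)F)cc2)s1`, returns only a limit of the assay in this assay, namely > 100 ug/mL, and not a number.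

Compound 2 therefore stands at the lowest of the two numbers reported. The nearest of them belongs to compound 1, whose number is higher by a gap that lies beyond the usual scatter of repeated measurements. The third value, that of compound 3, is a limit only, as the limit of > 100 ug/mL in this assay, at which 1 of the 3 values shown sits, records.

Compound 4, `CN(C(=O)NC(=O)c1c(F)cccc1F)c1nc(C(F)(F)F)c(C(=O)N/N=C/c2cc(C(F)(F)F)cc(C(F)(F)F)c2)s1`, has not yet been measured. It differs from compound 2 in one place: fluoro in place of hydrogen on an aromatic carbon, so that the 2-fluorophenyl group of compound 2 becomes a 2,6-difluorophenyl group. Among the compounds with values here, no pair of measured compounds shows this same change, so no measured step can be leaned on here. The step from compound 2 to compound 4 is expected to be small, a 1.0-fold higher number from compound 2 to compound 4 (0.01 log units; within the scatter), with no clear direction and nothing beyond the scatter. Compound 4 is accordingly expected to give about 5.5 ug/mL in this assay, most likely between 2.5 ug/mL and 12 ug/mL.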

Compound 4, half-maximal inhibitory concentration: 17.3 ug/mL
Compound 4: the middle estimate sits 3.1-fold (0.50 log units) below what was measured; measured number above the stated range.
By their numbers in this assay, from the lowest: compound 2; then compounds 1 and 4 (each within the scatter of the next). At a limit, above all of these: compound 3.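

In this assay, replacing the 2-fluorophenyl group with a 2,6-difluorophenyl group gives a 3.2-fold higher number from compound 2 to compound 4 (0.50 log units; beyond the scatter), which means weaker inhibition by a margin that repeat measurements would not explain. Within the data shown here, this is the first single-place step in the set, and it shows that this aromatic carbon, ortho to a large group, is not indifferent to a swap of hydrogen for fluoro, a change of only 1 heavy atom. No measurement shown bears on the reason for this step.

As far as these compounds go, at this place, compound 2 and compound 4 cover only hydrogen and fluoro, so it remains open whether a methoxy group, a chlorine atom or an amine would weaken inhibition as fluoro does, or would instead leave it unchanged or strengthen it. Among these compounds, this change also appears in only a single pair, and whether it would move the number in the same direction and by a similar amount on another compound remains open.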